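Fluoro for methoxy on the fused ring

The source may report more compounds than this note shows. Statements on the series, on what has been measured and on what is new or still open speak of the compounds shown alone.

As far as these compounds go, in an assay on RPMI-8226 cells for antagonist activity at P2X purinoceptor 7 (Homo sapiens), read by calcium flux (a higher number here means a weaker inhibitor, a lower number a stronger inhibitor), compound 3 `COc1ccc2c(ccn2CCCCN2CCN(C(c3ccccc3)c3ccccc3)CC2)c1` reports only a limit, > 10000 nM, so its own number is unknown (the limit of > 10000 nM in this assay, at which 1 of the 3 values shown sits). Compound 1 `Cc1cccc2c1ccn2CCCCN1CCN(C(c2ccccc2)c2ccccc2)CC1` gives 5300 nM and compound 2 `Cc1cccc2ccn(CCCCN3CCN(C(c4ccccc4)c4ccccc4)CC3)c12` gives 2300 nM; the change was an at least 1.8-fold higher number from compound 1 to compound 3 (0.27 log units; that floor lies within the scatter) and an at least 4.3-fold higher number from compound 2 to compound 3 (0.63 log units; beyond the scatter), while a 2.3-fold lower number from compound 1 to compound 2 (0.36 log units; beyond the scatter). Compound 4 `Fc1ccc2c(ccn2CCCCN2CCN(C(c3ccccc3)c3ccccc3)CC2)c1` differs from compound 3 by fluoro in place of methoxy on an aromatic carbon. Among the measured compounds shown here, no measured step exchanges these two groups, so the size of the move is open; the nearest evidence is compound 3 sitting at the limit > 10000 nM. For compound 4 the number is expected to stay near that region, estimated at 7000 nM with a range of 2500 nM to 20000 nM. The expected step is an at least 1.4-fold lower number from compound 3 to compound 4 (0.15 log units; that floor lies within the scatter), with a real chance that compound 4 again reads only a limit.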

Compound 4, half-maximal inhibitory concentration: 120 nM
Estimate against measurement, compound 4: 58-fold (1.77 log units) above; measured number below the stated range.
By their numbers in this assay, from the lowest: compound 4; then compound 2; then compound 1. At a limit, above all of these: compound 3.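

Compound 3 reads only a limit in this assay: the limit of > 10000 nM in this assay, at which 1 of the 4 values shown sits. On this aromatic carbon the group decides the reading, with fluoro in place of methoxy giving an at least 83-fold lower number from compound 3 to compound 4 (1.92 log units; beyond the scatter), a floor and not a full size. The 5-fluoro-1H-indol-1-yl group also improves on both methyl-bearing groups, with a 19-fold lower number from compound 2 to compound 4 (1.28 log units; beyond the scatter) and a 44-fold lower number from compound 1 to compound 4 (1.65 log units; beyond the scatter).

As far as these compounds go, the true size of the step from the limit stays open. Also open, from the compounds shown here alone, is whether chloro, nitrile or plain hydrogen on this carbon reads like fluoro, and whether a shorter chain keeps the gain.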